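This account rests on a few compounds, and the source may have more. Where it says the series, first, only, none or still open, it means among the compounds named here.

Measured compounds in a functional assay on HT-29 cells (Homo sapiens) for cytotoxicity, read by MTT assay, with a stated time of 72 h; on this read-out higher numbers stand for weaker inhibition and lower numbers for stronger inhibition:

compound 1 `COc1cc2c(Oc3ccc(NC(=O)c4nnn(-c5ccc(C)cc5)c4C(F)(F)F)cc3F)ccnc2cc1OCCCN1CCCC1` – 550 nM
compound 2 `COc1cc2c(Oc3ccc(NC(=O)c4nnn(-c5ccccc5C(F)(F)F)c4C)cc3F)ccnc2cc1OCCCN1CCCCC1` – 200 nM
compound 3 `COc1cc2c(Oc3ccc(NC(=O)c4nnn(-c5ccc(C)cc5)c4C(F)(F)F)cc3F)ccnc2cc1OCCCN1CCC(C)CC1` – 1200 nM

In this assay compound 3 gives the highest of the three numbers; compound 1 is the nearest, and compound 2 is the furthest away. Among the measured compounds shown here, the one single-site step in the set, a 2.2-fold higher number from compound 1 to compound 3 (0.34 log units; beyond the scatter), runs from compound 1 to compound 3 at the chain end, away from the place now under consideration.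

Compound 4 `COc1cc2c(Oc3ccc(NC(=O)c4nnn(-c5cccc(Br)c5)c4C(F)(F)F)cc3F)ccnc2cc1OCCCN1CCC(C)CC1` differs from compound 3 only at the group on the aromatic nitrogen: 3-bromophenyl in place of 4-methylphenyl on an aromatic nitrogen. For the measured compounds named here, no measured pair changes this group alone. Compound 2 carries a different group there as well, but it also differs from compound 3 in the substituent on the five-membered ring and at the chain end, so its value against that of compound 3 shows nothing about the 3-bromophenyl-for-4-methylphenyl exchange on its own. Going by the values given here, there is thus no step in the data that bears on the change, and no direction can be inferred from it.

For compound 4 the expectation is therefore a step of about a 1.2-fold lower number from compound 3 to compound 4 (0.08 log units; within the scatter), that is, no change beyond the scatter; compound 4 is estimated at 1000 nM, with a range of 400 nM to 2800 nM in this assay.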

Compound 4, half-maximal inhibitory concentration: 380 nM
Compound 4: middle estimate off by 2.6-fold (0.42 log units), on the high side, and the stated range ends above it.
By their numbers in this assay, from the lowest: compounds 2, 4 and 1 (each within the scatter of the next, the first and the last beyond it); then compound 3.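

In this assay, the group on the aromatic nitrogen proves able to move the number: with the 4-methylpiperidin-1-yl chain end and the trifluoromethyl group held fixed, the exchange gives a 3.2-fold lower number from compound 3 to compound 4 (0.50 log units; beyond the scatter). Among the compounds shown here, this is the first single-site step at this position, and it is of modest size, but it comes from a swap between groups with the same heavy-atom count and no hydrogen-bond donors or acceptors, so neither of those counts distinguishes them. Since 3-bromophenyl differs from 4-methylphenyl both in its substituent and in where that substituent sits on the phenyl ring, this one step cannot separate the two changes, and no measurement at hand accounts for it.

Still open, as far as these compounds go, is whether 3-methylphenyl or 4-bromophenyl would follow compound 4 or compound 3, and where unsubstituted phenyl or 3-chlorophenyl would fall at this position. Also open, from the compounds shown here alone, is whether the step carries over to other contexts, such as the pyrrolidin-1-yl chain end of compound 1 or a methyl group in place of trifluoromethyl on the five-membered ring.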